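A few compounds are considered here, and "the series" means these few. Any claim that something is new, unique, unknown or untested is made for them only; others in the source may bear on it.

Measured so far:
Compound 1, `CC(C)(C)Cc1c(-c2cccnc2)sc(N)c1C(=O)c1ccc(Cl)cc1`, gives 1%.
Compound 2, `CC(C)c1ccc(-c2sc(N)c(C(=O)c3ccc(Cl)cc3)c2CC(C)(C)C)cc1`, gives 1%.

Both values come from an assay on CHO cells for displacement of a labelled ligand from adenosine receptor A3 (Homo sapiens), read by scintillation counting, tested at 10 uM; a lower number here means less inhibition, a higher number more inhibition at the concentration tested (going by the name of the read-out). Compound 1 shows 1% there, and compound 2 shows 1%. The single measured step, no change at the digits printed from compound 1 to compound 2 (within the scatter), was no change within the scatter, and compound 2 therefore stands level with compound 1 at the digits shown; neither can be called stronger or weaker than the other.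

Compound 3, `Cc1noc(C)c1-c1sc(N)c(C(=O)c2ccc(Cl)cc2)c1CC(C)(C)C`, is the next compound to be read in this assay. It differs from compound 2 in one place: 3,5-dimethyl-1,2-oxazol-4-yl in place of 4-isopropylphenyl on an aromatic carbon. For the measured compounds named here, the one measured step that concerns this same aromatic carbon, no change at the digits printed from compound 1 to compound 2 (within the scatter), brought no change beyond the scatter, and the two measured compounds sit at the same low level. On that basis no step beyond the scatter is expected for compound 3 in this assay, and compound 3 is estimated at 3%, with a range from -5% to 15%. The expected step for compound 3 is therefore a number 2 percentage points higher from compound 2 to compound 3 (within the scatter), i.e. essentially none.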

Compound 3, a percentage reported as inhibition, at one concentration (the size of the read-out at that concentration, not a potency): 1%
Compound 3: the middle estimate sits 2 percentage points above what was measured; the measured number falls inside the stated range.
By their numbers in this assay, from the lowest: compounds 1, 2 and 3 (each within the scatter of the next).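

In this assay, the change at the aromatic carbon next to the ring sulfur now extends beyond six-membered rings: placing 3,5-dimethyl-1,2-oxazol-4-yl there in place of 4-isopropylphenyl gave no change at the digits printed from compound 2 to compound 3 (within the scatter), and placing it there in place of pyridin-3-yl gave no change at the digits printed from compound 1 to compound 3 (within the scatter). The entering group differs from 4-isopropylphenyl in ring size, in having 7 heavy atoms rather than 9, and in having 2 hydrogen-bond acceptors rather than 0, yet none of these differences separates compound 3 from the other two compounds in this read-out. No measurement shown here offers an explanation for this result.

As far as these compounds go, what the shared neopentyl, amino and (4-chlorophenyl)carbonyl groups contribute stays open, since all three compounds carry them and the only variation lies at this one aromatic carbon. From the compounds shown here alone, it also remains open whether a group of a different kind at that carbon, such as a carboxylic acid or a primary amine on a longer carbon chain, would move the number at all.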